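Quinolin-2-yl in place of 6-bromopyridin-2-yl

The compounds below may be only part of what the source reports. "The series", "measured", "known", "first", "only" and "open" are said of these compounds alone.

Measured in a functional assay on A549 cells (Homo sapiens) for antiproliferative activity, read by MTT assay; a higher number here means a weaker inhibitor, a lower number a stronger inhibitor:
- Compound 1 `O=C1N=C(N2CCC[C@H]2C(=O)Nc2ccc3ncnc(Nc4cccc(Cl)c4)c3c2)S/C1=C/c1cccc(Cl)c1`: > 50000 nM (a limit)
- Compound 2 `O=C1N=C(N2CCC[C@H]2C(=O)Nc2ccc3ncnc(Nc4cccc(Cl)c4)c3c2)S/C1=C/c1cccc(Br)n1`: 3100 nM

For the measured compounds named here, compound 2, at 3100 nM, holds the only actual number so far. Compound 3 `O=C1N=C(N2CCC[C@H]2C(=O)Nc2ccc3ncnc(Nc4cccc(Cl)c4)c3c2)S/C1=C/c1ccc2ccccc2n1` differs from it as follows: quinolin-2-yl in place of 6-bromopyridin-2-yl on a double-bonded chain carbon bound to a double-bonded ring carbon. Going by the values given here, one measured step bears on this change, at the same place: an at least 16-fold lower number from compound 1 to compound 2 (1.20 log units; beyond the scatter). That step is large, so a change here can move the read-out strongly. The incoming group keeps a six-membered aromatic ring with 1 hetero atom, so a smaller move towards a higher number in this assay is expected. The expected step is a 1.9-fold higher number from compound 2 to compound 3 (0.29 log units; within the scatter). For compound 3 the estimated value is 6000 nM, with an expected range from 1500 nM to 30000 nM.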

Compound 3, half-maximal inhibitory concentration: > 50000 nM
Compound 3 ended at the assay's limit; the forecaster's own chance of this, stated with the estimate: 20%; middle value at least 8.3-fold (0.92 log units) away from the limit.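

In this assay, quinolin-2-yl in place of 6-bromopyridin-2-yl gives an at least 16-fold higher number from compound 2 to compound 3 (1.20 log units; beyond the scatter). Keeping a six-membered aromatic ring with 1 hetero atom on the double-bonded chain carbon is therefore not enough to retain the measurable activity of compound 2. Compound 3 gives only a limit, and that limit recurs in the series: the limit of > 50000 nM in this assay, at which 2 of the 3 values shown sit.

The step from compound 1 to compound 3 cannot be read, as both values are limits. On these data alone, whether a pyridine ring carrying chlorine or an amine in place of the bromine retains activity stays open.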